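Swapping a Nitrile for a Nitrophenyl on the Hydrazone

The source may hold more compounds than are shown below. What is called first, only, known or untested is meant among the compounds shown, and "the series" means these compounds.

Of the compounds shown here, three sharing one core have been tested in a functional assay on MCF7 cells (Homo sapiens) for inhibition, read by MTT assay, with a stated time of 48 h; on this read-out higher numbers stand for weaker inhibition and lower numbers for stronger inhibition. Compound 2 `CCOC(=O)C1=C(N/N=C(/Cl)C#N)Nc2[nH]nc(C)c2C1c1ccc(N(C)C)cc1` gives 23200 nM, the second highest of the three numbers. Compound 1 `CCOC(=O)C1=C(N/C=N/c2ccc([N+](=O)[O-])cc2)Nc2[nH]nc(C)c2C1c1ccc(N(C)C)cc1` gives 58600 nM, and compound 3 `CCOC(=O)C1=C(N)Nc2[nH]nc(C)c2C1c1ccc(N(C)C)cc1`, which carries only a hydrogen on the amine nitrogen, gives 5060 nM. Within this set, the measured steps all point the same way: a 4.6-fold lower number from compound 2 to compound 3 (0.66 log units; beyond the scatter), a 12-fold lower number from compound 1 to compound 3 (1.06 log units; beyond the scatter), and a 2.5-fold lower number from compound 1 to compound 2 (0.40 log units; beyond the scatter).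

Compound 4 `CCOC(=O)C1=C(N/N=C(/Cl)c2ccc([N+](=O)[O-])cc2)Nc2[nH]nc(C)c2C1c1ccc(N(C)C)cc1` is compound 2 with a single change: 4-nitrophenyl in place of cyano on a carbon with a double bond to nitrogen. Within the data shown here, the entering group resembles the one carried by compound 1, the compound with the highest number of the three. The two steps that bear most directly on this change, a 2.5-fold lower number from compound 1 to compound 2 (0.40 log units; beyond the scatter) and a 4.6-fold lower number from compound 2 to compound 3 (0.66 log units; beyond the scatter), both show the number rising as more heavy atoms are placed on the amine nitrogen. An upward step is therefore expected, a 2.2-fold higher number from compound 2 to compound 4 (0.33 log units; beyond the scatter), modest but beyond the scatter. Compound 4 is estimated at 50000 nM, with a likely range from 20000 nM to 120000 nM.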

Compound 4, half-maximal inhibitory concentration: 52700 nM
Compound 4: middle estimate off by 1.1-fold (0.02 log units), on the low side; the range from low to high includes it.
By their numbers in this assay, from the lowest: compound 3; then compound 2; then compounds 4 and 1 (each within the scatter of the next).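

In this assay, the group on this carbon with a double bond to nitrogen clearly matters: putting 4-nitrophenyl in place of cyano gives a 2.3-fold higher number from compound 2 to compound 4 (0.36 log units; beyond the scatter), a modest but real move. Compared with the bare amine, the whole group of 12 heavy atoms gives a 10-fold higher number from compound 3 to compound 4 (1.02 log units; beyond the scatter), a large step, while a 1.1-fold lower number from compound 1 to compound 4 (0.05 log units; within the scatter) stays within the scatter, so two different links carrying 4-nitrophenyl cannot be told apart here. No supporting data explain why the numbers move this way.

As far as these compounds go, with only cyano and 4-nitrophenyl compared on this carbon, it stays open where a plain phenyl, a methyl or a carboxylic acid would fall. Also open, from the compounds shown here alone, is whether these steps would look the same in other cell types.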